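Swapping an aryl group for a hydroxyethyl chain on the pyrazole nitrogen

The source may report more compounds than this note shows. Statements on the series, on what has been measured and on what is new or still open speak of the compounds shown alone.

Among the compounds with values here, compound 1 `O=C(O)c1cc(-c2ccc(-c3ccc(Cl)cc3Cl)cc2)n(-c2ccc(Cl)cc2Cl)n1` is the stronger of the two compounds measured so far in an assay on isolated protein for inhibition of methionine--tRNA ligase, cytoplasmic (Homo sapiens) (a higher number here means a weaker inhibitor, a lower number a stronger inhibitor), where compound 1 gives 11900 nM. Its neighbour compound 2 `O=C(O)c1cc(-c2ccc(-c3ccc(F)cc3)cc2)n(-c2ccc(Cl)cc2Cl)n1` gives 41300 nM in this assay, and the step of a 3.5-fold higher number from compound 1 to compound 2 (0.54 log units; beyond the scatter) comes from a change on an aromatic carbon of the outer ring. Compound 3 `O=C(O)c1cc(-c2ccc(-c3ccc(Cl)cc3Cl)cc2)n(CCO)n1` is not yet measured; it differs from compound 1 in one place: 2-hydroxyethyl in place of 2,4-dichlorophenyl on an aromatic nitrogen. Within the data shown here, no measured step touches this nitrogen, so the one known step offers no direct guide, and the change removes a large ring in favour of a short chain, a kind of move that this small set has not tested. The expectation for compound 3 is therefore a weakening, with wide uncertainty, amounting to a 2.9-fold higher number from compound 1 to compound 3 (0.47 log units; beyond the scatter). Compound 3 is estimated at 35000 nM, within a range from 8000 nM to 150000 nM.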

Compound 3, half-maximal inhibitory concentration: > 100000 nM
Compound 3 gave a limit, no number (the forecaster's own chance of this, stated with the estimate: 30%); middle value at least 2.8-fold (0.45 log units) from the limit.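

Compound 3 gives only a limit of the assay, not a number: the limit of > 100000 nM in this assay, at which 1 of the 3 values shown sits. In this assay, within the data shown here, the first measured change on this aromatic nitrogen gives an at least 8.4-fold higher number from compound 1 to compound 3 (0.92 log units; beyond the scatter), so what sits on the nitrogen clearly matters to inhibition, and not only the outer ring touched by the earlier step. A short 2-hydroxyethyl chain cannot take the place of the 2,4-dichlorophenyl ring here without a loss, and the true size of that loss remains unknown because of the limit: the limit of > 100000 nM in this assay, at which 1 of the 3 values shown sits.

The compounds shown leave open whether the loss follows from removing the ring, removing its chlorine atoms, or adding the hydroxyl group. An unsubstituted phenyl ring on this nitrogen would test the chlorine atoms, while a plain ethyl chain would test the hydroxyl group.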